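Tetrabromo carbinol series: methyl against 4-chlorophenyl

The source may hold more compounds than are shown below. What is called first, only, known or untested is meant among the compounds shown, and "the series" means these compounds.

Measured in a functional assay on CCRF-CEM cells (Homo sapiens) for antiproliferative activity, read by MTT assay, with a stated time of 48 h, tested at 50 uM; a higher number here means a weaker effect of the compound at the concentration tested, a lower number a stronger effect:
compound 1 `COc1cccc(C(O)CCn2nc3c(Br)c(Br)c(Br)c(Br)c3n2)c1`: 2%
compound 2 `OC(CCn1nc2c(Br)c(Br)c(Br)c(Br)c2n1)c1ccc(Br)cc1`: 0%
compound 3 `CC(O)CCn1nc2c(Br)c(Br)c(Br)c(Br)c2n1`: 45%

Compound 3 stands highest of the three numbers in this assay; the steps to compound 1 and to compound 2 are both beyond the scatter. Compound 4 `OC(CCn1nc2c(Br)c(Br)c(Br)c(Br)c2n1)c1ccc(Cl)cc1` is not yet measured. It differs from compound 3 as follows: 4-chlorophenyl in place of methyl on a saturated chain carbon bound to an oxygen on a saturated carbon and a saturated chain carbon.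

Among the measured compounds shown here, two measured steps bear on this change, each going the opposite way, methyl entering where a ring leaves: a number 43 percentage points higher from compound 1 to compound 3 (beyond the scatter) and a number 45 percentage points higher from compound 2 to compound 3 (beyond the scatter). Between the two ring-bearing compounds the difference is small: a number 2 percentage points lower from compound 1 to compound 2 (within the scatter). A 4-chlorophenyl entering in place of methyl is therefore expected to lower the number by a large amount, a number 43 percentage points lower from compound 3 to compound 4 (beyond the scatter). For compound 4 the estimate in this assay is 2%, with a range from 0% to 12%.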

Compound 4, a percentage reported as activity, at one concentration (the size of the read-out at that concentration, not a potency): 0%
For compound 4 the middle estimate is 2 percentage points above the measured one; low and high end bracket the measured number.
By their numbers in this assay, from the lowest: compounds 2, 4 and 1 (each within the scatter of the next); then compound 3.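

In this assay 4-chlorophenyl in place of methyl gives a number 45 percentage points lower from compound 3 to compound 4 (beyond the scatter) and so shows the large drop directly, in the direction of adding the ring. Chloro in place of bromo on an aromatic carbon gives no change at the digits printed from compound 2 to compound 4 (within the scatter) and 4-chlorophenyl in place of 3-methoxyphenyl gives a number 2 percentage points lower from compound 1 to compound 4 (within the scatter) and with these steps the three ring-bearing compounds cannot be told apart at the concentration tested. No measurement shown accounts for the effect of the ring.

As far as these compounds go, whether the aromatic ring itself matters, or only a group larger than methyl, remains open. Unsubstituted phenyl, cyclohexyl, a longer chain or a ring carrying an amine would help to separate these readings, ideally with full dose-response measurements.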